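Exchanging the ring on a saturated carbon: a small step

This account rests on a few compounds, and the source may have more. Where it says the series, first, only, none or still open, it means among the compounds named here.

Compound 2 `CN1C[C@@H](c2cccs2)[C@@]2(Cc3ccccc3C2=O)[C@@]12C(=O)Nc1ccccc12` was tested in a functional assay on the whole organism (strain Wister albino) for inhibition, with Rattus norvegicus as the target, read by paw edema, with a stated time of 1 h, at a dose of 50 mg/kg by the intraperitoneal route (a higher number here means more inhibition at the dose given (going by the name of the read-out), a lower number less inhibition), where compound 2 gives 49.9%. Two close relatives were measured the same way. Compound 1 `Cc1ccc([C@@H]2CN(C)[C@]3(C(=O)Nc4ccccc43)[C@]23Cc2ccccc2C3=O)cc1` gives 56.4%, and compound 3 `CN1C(=O)[C@@]2(c3ccccc31)N(C)C[C@@H](c1cccs1)[C@@]21Cc2ccccc2C1=O` gives 33%. Compound 2 therefore sits second of the three: its number lies within the scatter of compound 1, and the only clear gap is a number 16.9 percentage points lower from compound 2 to compound 3 (beyond the scatter), where the change is methyl in place of hydrogen on an amide-type nitrogen in a ring.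

Compound 4 `COc1ccc([C@@H]2CN(C)[C@]3(C(=O)Nc4ccccc43)[C@]23Cc2ccccc2C3=O)cc1` differs from compound 2 in one place: 4-methoxyphenyl in place of thiophen-2-yl on a saturated ring carbon. Of the measured steps, only a number 6.5 percentage points lower from compound 1 to compound 2 (within the scatter) bears on this change, since it also exchanges the group on the same saturated ring carbon, thiophen-2-yl against 4-methylphenyl. That step was small and within the scatter, so the reverse move, a six-membered aromatic ring of carbon only replacing the five-membered aromatic ring with one hetero atom, is expected to be small as well. Within the data shown here, the 4-methoxyphenyl of compound 4 is not the 4-methylphenyl of compound 1, and no measured step shows what the methoxy group does, so the expectation is loose. Compound 4 is expected to give 55%, within a range from 42% to 68%. The expected step of a number 5.1 percentage points higher from compound 2 to compound 4 (within the scatter) is estimated to stay within the scatter.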

Compound 4, a percentage reported as inhibition, in the whole organism at one dose (the size of the read-out at that dose, not a potency): 41.2%
Estimate against measurement, compound 4: 13.8 percentage points above; measured number outside the range, below it.
By their numbers in this assay, from the lowest: compounds 3, 4, 2 and 1 (each within the scatter of the next, the first and the last beyond it).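

In this assay, exchanging the ring on the saturated carbon again gives a step within the scatter, a number 8.7 percentage points lower from compound 2 to compound 4 (within the scatter), so a five-membered aromatic ring with a sulfur atom and a six-membered aromatic ring of carbon only are not told apart here. Among these compounds, what the earlier compounds could not show is that the small group carried on the six-membered ring can matter: a number 15.2 percentage points lower from compound 1 to compound 4 (beyond the scatter), a step beyond the scatter, so the type of ring alone does not fix the number, as compound 1 and compound 4 share that ring type yet stand clearly apart. Nothing available explains why methoxy and methyl differ in this way.

The compounds shown leave open how a plain phenyl ring, or a phenyl ring carrying an amine, a carboxylic acid or a longer chain such as butoxy, would compare with methyl and methoxy in the same place. Going by these compounds, it also remains open whether methyl in place of hydrogen on the amide-type nitrogen gives a similar step when the saturated ring carbon carries 4-methoxyphenyl rather than thiophen-2-yl.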